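The compounds below may be only part of what the source reports. "The series", "measured", "known", "first", "only" and "open" are said of these compounds alone.

Working notes on the series. Within the data shown here, in a functional assay on HCT-8 cells (Homo sapiens) for cytotoxicity (a higher number here means that more compound is needed for the effect, a lower number that less compound is needed), compound 1 `COC1=C(C)C(=O)/C(=C(O)/C=C/c2ccc(OC)cc2)C(=O)C1(C)C` gives 5.6 ug/mL, the lowest of the two numbers so far; compound 2 `COC1=C(C)C(=O)/C(=C(O)/C=C/c2ccco2)C(=O)C1(C)C` gives 17.5 ug/mL. Among the measured compounds shown here, the only measured step at this position is a 3.1-fold higher number from compound 1 to compound 2 (0.49 log units; beyond the scatter), furan-2-yl in place of 4-methoxyphenyl. Compound 3 `COC1=C(C)C(=O)/C(=C(O)/C=C/c2nccs2)C(=O)C1(C)C` differs from compound 1 as 1,3-thiazol-2-yl in place of 4-methoxyphenyl on a double-bonded chain carbon bound to a double-bonded chain carbon. Because the furan step gave a 3.1-fold higher number from compound 1 to compound 2 (0.49 log units; beyond the scatter), a step of similar size and direction is expected here, a 2.7-fold higher number from compound 1 to compound 3 (0.43 log units; beyond the scatter). Compound 3 is estimated at 15 ug/mL, with a range from 6 ug/mL to 35 ug/mL.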

Compound 3, concentration for half-maximal effect: 5.1 ug/mL
Compound 3: the middle estimate sits 2.9-fold (0.47 log units) above what was measured; measured number below the stated range.
By their numbers in this assay, from the lowest: compounds 3 and 1 (each within the scatter of the next); then compound 2.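

In this assay the change to 1,3-thiazol-2-yl gives a 1.1-fold lower number from compound 1 to compound 3 (0.04 log units; within the scatter) and so shows that 4-methoxyphenyl can be given up at this place without a shift beyond the scatter. Set against furan-2-yl, the same group gives a 3.4-fold lower number from compound 2 to compound 3 (0.54 log units; beyond the scatter) and so the higher number of compound 2 does not extend to both five-membered aromatic rings shown here. From the compounds shown here alone, what an amine or a carboxylic acid on this chain carbon would give remains open. Nothing on hand accounts for the gap between the two five-membered rings.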